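This account rests on a few compounds, and the source may have more. Where it says the series, first, only, none or still open, it means among the compounds named here.

Measured so far in an assay on isolated protein for displacement of a labelled ligand from D(4) dopamine receptor (Homo sapiens); on this read-out higher numbers stand for weaker inhibition and lower numbers for stronger inhibition:
Compound 1 `O=C(NC1CCN(Cc2ccccc2Cl)CC1)c1cccc2ccccc12` gives 329 nM.
Compound 2 `O=C(NC1CCN(Cc2cccc(Br)c2)CC1)c1cccc2ccccc12` gives 66 nM.
Compound 3 `COc1ccc(CN2CCC(NC(=O)c3cccc4ccccc34)CC2)cc1` gives 223 nM.

Compound 2 has the lowest number of the three, with a 3.4-fold higher number from compound 2 to compound 3 (0.53 log units; beyond the scatter) and a 5.0-fold lower number from compound 1 to compound 2 (0.70 log units; beyond the scatter) both beyond the scatter. Compound 4 `Cc1ccccc1CN1CCC(NC(=O)c2cccc3ccccc23)CC1` differs from compound 2 in one place: 2-methylphenyl in place of 3-bromophenyl on a saturated chain carbon bound to an amine nitrogen in a ring. Among the compounds with values here, the step that bears on this is the one from compound 1, which carries 2-chlorophenyl at the same place, to compound 2: a 5.0-fold lower number from compound 1 to compound 2 (0.70 log units; beyond the scatter). Moving away from 3-bromophenyl toward a 2-substituted phenyl is therefore expected to raise the number in this assay by a modest amount, roughly a 3.3-fold higher number from compound 2 to compound 4 (0.52 log units; beyond the scatter). Compound 4 is estimated at 220 nM, within a range of 90 nM to 550 nM.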

Compound 4, inhibition constant: 155 nM
The estimate for compound 4 lay 1.4-fold (0.15 log units) above the measured number; the range from low to high includes it.
By their numbers in this assay, from the lowest: compound 2; then compounds 4, 3 and 1 (each within the scatter of the next, the first and the last beyond it).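

Methyl in place of chloro on the aromatic carbon gives a 2.1-fold lower number from compound 1 to compound 4 (0.33 log units; beyond the scatter) and shows that the group at this spot on the phenyl ring counts, not only its place. 2-Methylphenyl in place of 3-bromophenyl gives a 2.3-fold higher number from compound 2 to compound 4 (0.37 log units; beyond the scatter) and leaves compound 2 with the lowest number of the four. 2-Methylphenyl in place of 4-methoxyphenyl gives a 1.4-fold lower number from compound 3 to compound 4 (0.16 log units; within the scatter) and separates neither compound from the other.

Nothing available explains these differences. Still open, on these data alone, is how an amine or a carboxylic acid on the phenyl ring would compare.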